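A few compounds are considered here, and "the series" means these few. Any claim that something is new, unique, unknown or untested is made for them only; others in the source may bear on it.

Measured so far:
Compound 1, `COc1cccc(-c2nc(SCC(=O)c3sc(-c4ccccc4)nc3C)[nH]c(=O)c2C#N)c1`: 90.2%
Compound 2, `Cc1nc(-c2ccc(Cl)cc2)sc1C(=O)CSc1nc(-c2cccc(Cl)c2)c(C#N)c(=O)[nH]1`: 95.2%
Compound 3, `COc1ccc(-c2nc(SCC(=O)c3sc(-c4ccc(Cl)cc4)nc3C)[nH]c(=O)c2C#N)cc1OC`: 83.3%

All three numbers come from a functional assay on U-87MG ATCC cells for antiproliferative activity against U-87 MG (Homo sapiens), read by MTT assay, with a stated time of 48 h, tested at 10 uM; a higher number here means a weaker effect of the compound at the concentration tested, a lower number a stronger effect. Compound 3 sits beyond the scatter below compound 2, as the step of a number 11.9 percentage points lower from compound 2 to compound 3 (beyond the scatter) shows, while the gap between compound 3 and compound 1 lies within the scatter, so no order can be read between those two.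

Compound 4, `COc1cccc(-c2nc(SCC(=O)c3sc(-c4ccc(Cl)cc4)nc3C)[nH]c(=O)c2C#N)c1`, has not yet been measured. Its difference from compound 3 is hydrogen in place of methoxy on an aromatic carbon.

Among the measured compounds shown here, no measured step removes a methoxy group in this way; the only measured step, a number 11.9 percentage points lower from compound 2 to compound 3 (beyond the scatter), swaps a whole chlorophenyl for a dimethoxyphenyl and is therefore only a loose guide. Compound 1, which already carries 3-methoxyphenyl, gives 90.2%, within the scatter of compound 3. The expected step is therefore small, a number 4.7 percentage points higher from compound 3 to compound 4 (within the scatter), with no direction beyond the scatter. Compound 4 is estimated at 88%, within a range from 78% to 98%.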

Compound 4, a percentage reported as activity, at one concentration (the size of the read-out at that concentration, not a potency): 89.7%
Compound 4: middle estimate off by 1.7 percentage points, on the low side; the range from low to high includes it.
By their numbers in this assay, from the lowest: compounds 3, 4, 1 and 2 (each within the scatter of the next, the first and the last beyond it).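

In this assay, the methoxy group para to a large group can go without a readable effect: the step is a number 6.4 percentage points higher from compound 3 to compound 4 (within the scatter). The two other single exchanges, a number 5.5 percentage points lower from compound 2 to compound 4 (within the scatter) for methoxy in place of chloro and a number 0.5 percentage points lower from compound 1 to compound 4 (within the scatter) for chloro in place of hydrogen on the other aryl group, also stay within the scatter, so neither can be read as having an effect on its own. The earlier gap, a number 11.9 percentage points lower from compound 2 to compound 3 (beyond the scatter), now has a compound lying within the scatter of both ends, so it appears only when the chloro-to-methoxy exchange and the added methoxy are taken together.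

No evidence on why these numbers fall as they do bears on this result. From the compounds shown here alone, whether an amine or a carboxylic acid at this position of the six-membered aromatic ring would move the read-out beyond the scatter stays open.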